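From Hydroxymethyl to Carboxy on the Shared Core

The source may report more compounds than this note shows. Statements on the series, on what has been measured and on what is new or still open speak of the compounds shown alone.

Compound 1 `O=C(CCl)N1CCCC(n2nc(-c3ccc(Oc4ccccc4)cc3)cc2CO)C1` carries a hydroxymethyl group on the shared core together with a chloroacetyl piperidine. Within the data shown here, in a functional assay on JeKo-1 cells (Homo sapiens) for inhibition, read by luminescence and CellTiter-Glo, with a stated time of 72 h (on this read-out lower numbers stand for stronger inhibition and higher numbers for weaker inhibition), compound 1 gives 7800 nM, the only value in this set reported as a number. Compound 2 `C/C=C/C(=O)Nc1ccc(Cn2nc(-c3ccc(Oc4ccccc4)cc3)cc2C(=O)O)cc1` carries a carboxy group and a crotonamide-bearing benzyl substituent; in this assay compound 2 reaches only the limit, > 60000 nM. Compound 3 `C/C=C/C(=O)Nc1cccc(Cn2nc(-c3ccc(Oc4ccccc4)cc3)cc2C(=O)O)c1` is an isomer of compound 2. In this assay compound 3 likewise shows only a limit, > 60000 nM. Two of the three values thus stand at the limit (the limit of > 60000 nM in this assay, at which 2 of the 3 values shown sit).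

Compound 4 `O=C(O)c1cc(-c2ccc(Oc3ccccc3)cc2)nn1C1CCCN(C(=O)CCl)C1` keeps the chloroacetyl piperidine of compound 1 and changes a single group: carboxy in place of hydroxymethyl on an aromatic carbon. Among the measured compounds shown here, no measured pair shows this change on its own. Compound 2 carries the carboxy group and stands at the limit. Compound 3 does the same. Compound 1 lacks it and gives a number. On that ground the expected step is a 3.2-fold higher number from compound 1 to compound 4 (0.51 log units; beyond the scatter), toward weaker inhibition. Compound 4 is therefore estimated at 25000 nM, within a range of 7000 nM to 60000 nM, with a fair chance that only a limit is reported.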

Compound 4, half-maximal inhibitory concentration: 3600 nM
Beside the measured number, compound 4's estimate is 6.9-fold (0.84 log units) above it, and the stated range ends above it.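

With the chloroacetyl piperidine kept, carboxy in place of hydroxymethyl on an aromatic carbon gives a 2.2-fold lower number from compound 1 to compound 4 (0.34 log units; beyond the scatter) in this assay. Among these compounds, this is the first direct reading of the change on the shared core, and it runs toward stronger inhibition, not weaker. At this position, next to the ring nitrogen, the carboxy group goes with a measured number and not a limit, so the group does not by itself hold a compound at the limit: the limit of > 60000 nM in this assay, at which 2 of the 4 values shown sit.

Among the compounds shown here, only this one pair reads the change, so it stays open whether the same step would appear with the crotonamide-bearing benzyl substituent or any other group in place of the chloroacetyl piperidine. The compounds shown also leave open how a methyl ester, a primary amide or an aminomethyl group would fare at this position.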